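The compounds below may be only part of what the source reports. "The series", "measured", "known", "first", "only" and "open" are said of these compounds alone.

Values in a functional assay on A549 cells (Homo sapiens) for antiproliferative activity, read by MTT assay (on this read-out lower numbers stand for stronger inhibition and higher numbers for weaker inhibition), so far:
compound 1 (`COc1cc2c(Oc3ccc(NC(=O)Nc4ccccc4Cl)cc3)ccnc2cc1OCCCCCCC(=O)NO`) gives 1910 nM
compound 2 (`COc1cc2c(Oc3ccc(NC(=O)Nc4ccc(OC(F)(F)F)cc4)cc3)ccnc2cc1OCCCCCCC(=O)NO`) gives 3130 nM
compound 3 (`COc1cc2c(Oc3ccc(NC(=O)Nc4ccc(Cl)c(C(F)(F)F)c4)cc3)ccnc2cc1OCCCCCCC(=O)NO`) gives 5020 nM

Compound 2 lies inside the span set by compound 1 and compound 3, and it is within the scatter of both: a 1.6-fold higher number from compound 1 to compound 2 (0.21 log units; within the scatter) on one side and a 1.6-fold higher number from compound 2 to compound 3 (0.21 log units; within the scatter) on the other. The one gap beyond the scatter is the modest 2.6-fold higher number from compound 1 to compound 3 (0.42 log units; beyond the scatter) between the two outer compounds.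

Next in the series is compound 4 (`COc1cc2c(Oc3ccc(NC(=O)Nc4ccc(C)cc4C)cc3)ccnc2cc1OCCCCCCC(=O)NO`), not yet measured. Its difference from compound 2 is 2,4-dimethylphenyl in place of 4-(trifluoromethoxy)phenyl on an amide-type nitrogen in words, 2,4-dimethylphenyl in place of 4-(trifluoromethoxy)phenyl on an amide-type nitrogen.

Within the data shown here, all three measured steps exchange the group at this same place, so they are the only guide to the size of the step. Two of them stay within the scatter and the third is modest. Among the measured compounds shown here, none of the measured compounds carries 2,4-dimethylphenyl, so the guide is loose and no direction can be read from it. In this assay no step beyond the scatter is therefore expected.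

The estimate amounts to a 1.1-fold lower number from compound 2 to compound 4 (0.05 log units; within the scatter) as the expected step. Compound 4 is expected at 2800 nM with an estimated range from 1200 nM to 6500 nM for now.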

Compound 4, half-maximal inhibitory concentration: 5490 nM
Compound 4: the middle estimate sits 2.0-fold (0.29 log units) below what was measured; measured number inside the range.
By their numbers in this assay, from the lowest: compounds 1, 2, 3 and 4 (each within the scatter of the next, the first and the last beyond it).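

Compound 4 is the only one of the four whose group on the amide-type nitrogen is built of carbon alone, and in this assay that all-carbon 2,4-dimethylphenyl gives a 1.8-fold higher number from compound 2 to compound 4 (0.24 log units; within the scatter) and a 1.1-fold higher number from compound 3 to compound 4 (0.04 log units; within the scatter), so it is not separated from either the 4-(trifluoromethoxy)phenyl or the 4-chloro-3-(trifluoromethyl)phenyl group. Halogen on this ring is therefore not required to reach the level of compound 2 and compound 3 in this series. The only gap of the new compound beyond the scatter is the modest 2.9-fold higher number from compound 1 to compound 4 (0.46 log units; beyond the scatter), so the 2-chlorophenyl of compound 1 now stands apart from two of the other groups, though not from the 4-(trifluoromethoxy)phenyl of compound 2; nothing available here bears on why these groups compare as they do.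

Open, as far as these compounds go, is whether any group at this position moves the number well beyond this narrow band, for instance an unsubstituted phenyl, a pyridine ring, or a phenyl carrying an amine or a carboxylic acid. Also open, from the compounds shown here alone, is whether a single methyl would compare with the 2-chlorophenyl of compound 1 or with the 2,4-dimethylphenyl of compound 4.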